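The compounds below may be only part of what the source reports. "The series", "measured", "known", "first", "only" and "open" are said of these compounds alone.

Measured compounds:
- compound 1, `Nc1nccc(-c2ccc3nc(C4COc5ccc(F)cc5C4)oc3c2)n1`: 28 nM
- compound 2, `Nc1nccc(-c2ccc3nc(C4COc5ccc(F)cc5C4)[nH]c3c2)n1`: "not determined" (no result reported)

The series rests on a shared core that carries an aminopyrimidine on one side and a fused bicyclic ether on the other. In an assay on cells for inhibition of Rho-associated protein kinase 2 (Homo sapiens) (on this read-out lower numbers stand for stronger inhibition and higher numbers for weaker inhibition), compound 1 gives 28 nM. Compound 2 has the same fused bicyclic ether with a fluoro group, but its core differs in one ring position; in this assay compound 2 gives "not determined" (no result reported), so no number stands against it and it cannot be placed on the scale at all. Compound 3, `COc1ccc2c(c1)CC(c1nc3ccc(-c4ccnc(N)n4)cc3[nH]1)CO2`, keeps the core of compound 2 and changes the substituent on the outer ring: methoxy in place of fluoro on an aromatic carbon. Going by the values given here, with no measured step available, the expectation can only be broad: in this assay the step from compound 2 to compound 3 is expected to be small, in no particular direction, and probably not beyond the usual scatter. For compound 3 the estimated potency in this assay is 35 nM, with a range from 8 nM to 150 nM.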

Compound 3, half-maximal inhibitory concentration: 99 nM
For compound 3 the middle estimate is 2.8-fold (0.45 log units) below the measured one; the measured number falls inside the stated range.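

No step can be read from compound 2 to compound 3: in this assay compound 2 gives "not determined" (no result reported) and so offers no number to set against compound 3. The compounds shown leave open how far methoxy in place of fluoro on the same core moves potency. No evidence here bears on this result.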